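This account rests on a few compounds, and the source may have more. Where it says the series, first, only, none or still open, it means among the compounds named here.

Of the compounds shown here, two have so far been read in an in vitro ADME assay on microsomes (Homo sapiens) for metabolic stability, read by LC-MS, with a stated time of 15 min; a higher number here means that the compound lasts longer, a lower number that the compound disappears faster. Compound 1 `O=C(Nc1ccc(CO)cc1)Nc1ccc(-c2nc(N3C4CCC3COC4)nc(N3C4CCC3COC4)n2)cc1` gives < 0.0167 h, which is a limit of the assay and not a number. Among the compounds with values here, compound 2 `CN1CCN(c2ccc(NC(=O)Nc3ccc(-c4nc(N5C6CCC5COC6)nc(N5[C@H](CO)CC[C@@H]5CO)n4)cc3)cc2)CC1` gives 0.0917 h, the only true number available, so its standing cannot yet be judged against a second measured half-life. The compound to be tested next is compound 3 `CC(C)Nc1nc(-c2ccc(NC(=O)Nc3ccc(N4CCN(C)CC4)cc3)cc2)nc(N2C3CCC2COC3)n1`, and its difference from compound 2 is isopropylamino in place of 2,5-bis(hydroxymethyl)pyrrolidin-1-yl on an aromatic carbon. In words, isopropylamino stands in place of 2,5-bis(hydroxymethyl)pyrrolidin-1-yl on an aromatic carbon of a six-membered aromatic ring with 3 nitrogen, between two ring nitrogen atoms. Within the data shown here, no measured pair isolates this change, so any expectation rests on thin ground. Compound 1 also lacks the 2,5-bis(hydroxymethyl)pyrrolidin-1-yl group, though it differs elsewhere too, and its < 0.0167 h is again a limit. A shorter half-life is therefore expected, with an estimated change of a 1.8-fold lower number from compound 2 to compound 3 (0.26 log units; within the scatter), about the size of the usual scatter. For compound 3 the estimated half-life is 0.05 h, with an expected range of 0.02 h to 0.14 h.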

Compound 3, half-life: > 0.5 h
Compound 3 was reported as a limit (the forecaster's own chance of this, stated with the estimate: 15%); middle value at least 10-fold (1.00 log units) away from the limit.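

Within the data shown here, replacing 2,5-bis(hydroxymethyl)pyrrolidin-1-yl with isopropylamino on an aromatic carbon between two ring nitrogen atoms gives, in this assay, an at least 5.4-fold higher number from compound 2 to compound 3 (0.73 log units; beyond the scatter), the first comparison here of compounds that differ in one place. This shows that the group at this position bears on the half-life, and that the longer half-life goes with the smaller, ring-free isopropylamino group, although this single pair cannot assign a cause. Compound 3 is reported as a limit of the assay, so the step gives only a lower bound and not its full size: the limit of > 0.5 h in this assay, at which 1 of the 3 values shown sits.

Going by these compounds, it remains open whether the longer half-life comes from the isopropylamino group itself or from the loss of the two hydroxymethyl groups, a question that an unsubstituted pyrrolidin-1-yl, a dimethylamino or a cyclopropylamino group at the same place would help to separate. On these data alone, compound 1 differs from compound 2 and compound 3 in more than one place, so it is also open whether the same change would have a similar effect on the rest of that molecule.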